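This account rests on a few compounds, and the source may have more. Where it says the series, first, only, none or still open, it means among the compounds named here.

For the measured compounds named here, in a functional assay on DU-145 cells (Homo sapiens) for inhibition, read by trypan blue exclusion, with a stated time of 96 h (a lower number here means a stronger inhibitor of growth, a higher number a weaker inhibitor of growth), compound 2 (`COc1cc(OC)c(/C=C(\C(=O)c2ccc(Br)cc2)S(=O)(=O)Cc2ccc(Cl)cc2)c(OC)c1`) gives 25000 nM and holds the higher of the two numbers so far. Compound 1 (`COc1cc(OC)c(/C=C(/SCc2ccc(Cl)cc2)C(=O)c2ccc(Br)cc2)c(OC)c1`) gives 1000 nM on the same scale. Compound 3 (`COc1cc(OC)c(/C=C(\C(=O)c2ccc(Br)cc2)S(=O)(=O)c2ccc(C)cc2)c(OC)c1`) carries 4-methylphenyl in place of 4-chlorobenzyl on a sulfonyl sulfur, and the rest of the structure stays as in compound 2. Going by the values given here, the one measured step, a 25-fold higher number from compound 1 to compound 2 (1.40 log units; beyond the scatter), is large, but it changes (4-chlorobenzyl)sulfanyl to (4-chlorobenzyl)sulfonyl and leaves the 4-chlorobenzyl in place. Among the compounds with values here, it therefore gives no direct size for this exchange, and no measured step covers it. The expected step, a 1.4-fold lower number from compound 2 to compound 3 (0.14 log units; within the scatter), is estimated to stay within the scatter, with little weight on its direction. Compound 3 is estimated at 18000 nM (5000 nM to 60000 nM).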

Compound 3, concentration for 50% growth inhibition: > 100000 nM
Compound 3 gave a limit, no number; the forecaster's own chance of this, stated with the estimate: 15%; middle value at least 5.5-fold (0.74 log units) from the limit.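

In this assay compound 3 gives > 100000 nM, which is a limit of the assay and not a number. The group on the sulfonyl sulfur is therefore not a neutral exchange: 4-methylphenyl in place of 4-chlorobenzyl gives an at least 4.0-fold higher number from compound 2 to compound 3 (0.60 log units; beyond the scatter), and the full change from (4-chlorobenzyl)sulfanyl to (4-methylphenyl)sulfonyl gives an at least 100-fold higher number from compound 1 to compound 3 (2.00 log units; beyond the scatter). Both steps are lower bounds, and their full size cannot be read: the limit of > 100000 nM in this assay, at which 1 of the 3 values shown sits.

The exchange alters both the ring substituent and the link to the sulfur, and these compounds do not separate the two; a 4-methylbenzyl group on the sulfonyl sulfur would do so. For the compounds shown here, also open is how 4-methylphenyl behaves on a sulfanyl sulfur, where the series so far holds only 4-chlorobenzyl.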